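Ring swap on the aromatic nitrogen of the sulfonyl series

The source may report more compounds than this note shows. Statements on the series, on what has been measured and on what is new or still open speak of the compounds shown alone.

Compound 1 `O=S(=O)(c1cccc(F)c1)c1cn(C2CCNC2)c2ncccc12` gives 44% in a functional assay on HeLa cells for agonist activity at 5-hydroxytryptamine receptor 6 (Homo sapiens), read by cAMP accumulation and immunoassay; on this read-out lower numbers stand for smaller maximal responses and higher numbers for larger maximal responses. Two measured neighbours differ from it only in the group on the sulfonyl sulfur: compound 2 `O=S(=O)(c1ccc(F)cc1)c1cn(C2CCNC2)c2ncccc12` gives 50% in this assay, and compound 3 `O=S(=O)(c1cccc(C(F)(F)F)c1)c1cn(C2CCNC2)c2ncccc12` gives 41%. Both steps are small: a number 6 percentage points higher from compound 1 to compound 2 (within the scatter), and a number 3 percentage points lower from compound 1 to compound 3 (within the scatter). Compound 1 thus sits between the values of compound 3 and compound 2, and the three numbers cannot be told apart within the scatter.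

Compound 4 `CC(C)N1CCCC(n2cc(S(=O)(=O)c3cccc(F)c3)c3cccnc32)C1` has not been measured. It differs from compound 1 at a different site: 1-isopropylpiperidin-3-yl in place of pyrrolidin-3-yl on an aromatic nitrogen. Within the data shown here, neither measured step bears on this change; both concern the group on the sulfonyl sulfur, and no measured pair varies the group on the aromatic nitrogen. The measured steps show only that the maximal response of this core has so far stayed within a narrow band. No direction for compound 4 can be derived from the data.

The expected value for compound 4 in this assay is therefore set at that of compound 1 with a wide range, 44% (20% to 68%). The step this estimate means is no change at the digits printed from compound 1 to compound 4 (within the scatter), expected to stay within the scatter, with low confidence.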

Compound 4, largest response reached (Emax), in percent of the reference or control that the assay uses: 67%
Compound 4: the middle estimate sits 23 percentage points below what was measured; measured number inside the range.
By their numbers in this assay, from the lowest: compounds 3, 1 and 2 (each within the scatter of the next); then compound 4.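

Among these compounds, the group on the aromatic nitrogen is the first site where a one-place change goes beyond the scatter in this assay: the step is a number 23 percentage points higher from compound 1 to compound 4 (beyond the scatter), whereas both changes on the sulfonyl sulfur stayed within it. The swap alters several features at once: a six-membered non-aromatic ring enters for a five-membered one, the heavy atoms of the group go from 5 to 9, and the hydrogen-bond donors go from 1 to 0, so this single step cannot assign the higher maximal response to any one of them. No measurement at hand accounts for the step.

Still open, as far as these compounds go, is how the step divides between the ring and the isopropyl group, which piperidin-3-yl with a hydrogen on the ring nitrogen and 1-isopropylpyrrolidin-3-yl would separate. Also open, from the compounds shown here alone, is whether the same change on the aromatic nitrogen holds with 4-fluorophenyl or a 3-trifluoromethylphenyl group on the sulfonyl sulfur, and whether a longer chain such as 1-butyl on the ring nitrogen continues the step.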